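The source may report more compounds than this note shows. Statements on the series, on what has been measured and on what is new or still open speak of the compounds shown alone.

In a functional assay on HCT-116 cells (Homo sapiens) for antiproliferative activity, read by MTT assay, with a stated time of 24 h (a lower number here means a stronger inhibitor, a higher number a weaker inhibitor), the measured compounds read as follows.

Compound 1 `COc1cc(OC)c(-c2coc3cc(OCC=C(C)C)ccc3c2=O)cc1OC` gives 680 nM
Compound 2 `COc1cc(OC)c(-c2coc3cc(OCc4ccccc4)ccc3c2=O)cc1OC` gives 2280 nM
Compound 3 `COc1cc(OC)c(-c2coc3cc(OCc4ccccc4C)ccc3c2=O)cc1OC` gives 2900 nM

Two kinds of step fix where compound 3 stands. Adding a methyl to an aromatic carbon moves the number only within the scatter (a 1.3-fold higher number from compound 2 to compound 3 (0.10 log units; within the scatter)), so the two aromatic members of the series cannot be separated. Replacing the 2-methylprop-1-en-1-yl group gives larger steps beyond the scatter, namely a 3.4-fold higher number from compound 1 to compound 2 (0.53 log units; beyond the scatter) and a 4.3-fold higher number from compound 1 to compound 3 (0.63 log units; beyond the scatter), and both lead upward.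

Compound 4 `COc1cc(OC)c(-c2coc3cc(OCc4ccc(C#N)cc4)ccc3c2=O)cc1OC` keeps the shared core, and the change is 4-cyanophenyl in place of 2-methylphenyl on a saturated chain carbon bound to an oxygen on an aromatic ring, with 4-cyanophenyl in place of 2-methylphenyl on a saturated chain carbon bound to an oxygen on an aromatic ring. Within the data shown here, no measured compound carries a nitrile, so the data do not test that group directly. The closest evidence is the substituent change on the same kind of ring (a 1.3-fold higher number from compound 2 to compound 3 (0.10 log units; within the scatter)), while the larger steps swapped the whole group. Compound 4 retains the aromatic ring, so no step beyond the scatter is expected in this assay. The expected step is a 1.2-fold lower number from compound 3 to compound 4 (0.08 log units; within the scatter), which remains an estimate. For compound 4 the estimated value is 2400 nM, with an expected range from 900 nM to 6000 nM.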

Compound 4, half-maximal inhibitory concentration: 4220 nM
Beside the measured number, compound 4's estimate is 1.8-fold (0.25 log units) below it, and the stated range covers the measured number.
By their numbers in this assay, from the lowest: compound 1; then compounds 2, 3 and 4 (each within the scatter of the next).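

In this assay, placing 4-cyanophenyl on the saturated chain carbon bound to an oxygen on an aromatic ring gives a step within the scatter against 2-methylphenyl (a 1.5-fold higher number from compound 3 to compound 4 (0.16 log units; within the scatter)) and also against unsubstituted phenyl (a 1.9-fold higher number from compound 2 to compound 4 (0.27 log units; within the scatter)), so compounds 2, 3 and 4 cannot be separated, even though the nitrile differs from the methyl in kind and in where it sits on the ring. The step from 2-methylprop-1-en-1-yl stays beyond the scatter (a 6.2-fold higher number from compound 1 to compound 4 (0.79 log units; beyond the scatter)), so the one clear division at this position still lies between that group and the three aromatic ones, with compound 1 the most potent of the four. No measurement at hand accounts for either the division or the flatness among the aromatic members.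

The compounds shown leave open whether an amine or a carboxylic acid on the phenyl ring would move the number beyond the scatter, as neither the methyl nor the nitrile does. They also leave open whether the advantage of compound 1 depends on its double bond, which a fully saturated chain such as 3-methylbutyl would test.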